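The source may report more compounds than this note shows. Statements on the series, on what has been measured and on what is new or still open speak of the compounds shown alone.

Measured so far:

compound 1, `COc1ccc(C(C)NC(=O)/N=C(\N)NCCCc2sc(N)nc2C)cc1`: 0.91
compound 2, `Cc1nc(N)sc1CCCN/C(N)=N/C(=O)N[C@@H](C)c1ccccc1`: 1.08
compound 3, `Cc1nc(N)sc1CCCN/C(N)=N/C(=O)NC(C)c1ccc(Cl)cc1`: 0.93

All three were tested in a functional assay on Right cardiac atrium for agonist activity at histamine H2 receptor (Cavia porcellus), with a stated time of 30 min, in the presence of a further agent that is not named here; a lower number here means a smaller maximal response, a higher number a larger maximal response. Compound 2 gives the highest number of the three, beyond the usual scatter above compound 3, which stands nearest to it, and further still above compound 1, the lowest. Among the measured compounds shown here, the only single-point step measured so far, a number 0.020 higher from compound 1 to compound 3 (within the scatter), is within the scatter, so swapping one group on the aromatic ring hardly moved the maximal response.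

Compound 4, `CCCCCCNC(=O)/N=C(\N)NCCCc1sc(N)nc1C`, has not yet been measured. It differs from compound 2 in one place: hexyl in place of 1-phenylethyl on an amide-type nitrogen. For the measured compounds named here, no measured step bears directly on this change, since the only step available kept the ring and altered a group on it, and here the ring itself is replaced by an open chain. The shared core carrying the aminothiazole end is untouched in every compound, and all three give a response close to the reference agonist, so a large drop is not expected.

Compound 4 is therefore estimated at 0.97, with a range from 0.8 to 1.1; the expected step a number 0.11 lower from compound 2 to compound 4 (beyond the scatter) is a small lowering, near the edge of the scatter.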

Compound 4, intrinsic activity: the largest response reached, as a fraction of the reference agonist's: 0.95
Beside the measured number, compound 4's estimate is 0.020 above it, and the stated range covers the measured number.
By their numbers in this assay, from the lowest: compounds 1, 3 and 4 (each within the scatter of the next); then compound 2.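

In this assay, the group on the amide-type nitrogen need not carry an aromatic ring for a large maximal response: hexyl, an open chain with no ring, gives a number 0.13 lower from compound 2 to compound 4 (beyond the scatter), a modest step. The earlier step changed only a group on the ring, whereas this one replaces the whole 1-phenylethyl group and shows that the ring and the defined stereocentre can go together at a cost beyond the scatter, yet without a large collapse. Nothing measured here accounts for this lowering.

This single step changes the ring, the stereocentre and the carbon count at once, so their separate shares cannot be told apart. Still open, from the compounds shown here alone, is how a cyclohexyl ring, a shorter butyl chain or a longer octyl chain would behave at this position.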